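Adding one methoxy group to compound 3

The source may hold more compounds than are shown below. What is called first, only, known or untested is meant among the compounds shown, and "the series" means these compounds.

Compound 1 `COc1cc([C@@H](O)COC(=O)/C=C/c2ccccc2)cc(OC)c1OC` gives 122000 nM
Compound 2 `COc1ccc([C@@H](O)COC(=O)/C=C/c2ccccc2)cc1` gives 23300 nM
Compound 3 `COc1cc2ccc([C@@H](COC(=O)/C=C/c3cc(OC)c(OC)c(OC)c3)OC(=O)/C=C/c3cc(OC)c(OC)c(OC)c3)cc2cc1OC` gives 55700 nM

In an ADME assay on Vero cells (Chlorocebus sabaeus) for cytotoxicity, read by MTT assay, with a stated time of 72 h (on this read-out higher numbers stand for lower toxicity in this test and lower numbers for higher toxicity in this test), compound 3 sits in the middle of these three values, with compound 1 higher and compound 2 lower, both gaps beyond the usual scatter. Compound 4 `COc1cc(/C=C/C(=O)OC[C@@H](OC(=O)/C=C/c2cc(OC)c(OC)c(OC)c2)c2ccc3c(OC)c(OC)c(OC)cc3c2)cc(OC)c1OC` differs from compound 3 in one place (methoxy in place of hydrogen on an aromatic carbon): methoxy in place of hydrogen on an aromatic carbon, ortho to a methoxy group. Among the compounds with values here, no measured pair differs in a single place, so no direct precedent exists. For this one small addition, no step beyond the scatter is expected in this assay here. The estimated change (a 1.1-fold lower number from compound 3 to compound 4 (0.05 log units; within the scatter)) is expected to be slight. The expected range rests on the spread from compound 2 (23300 nM) to compound 1 (122000 nM). For compound 4 the estimated value is 50000 nM (expected range 22000 nM to 120000 nM).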

Compound 4, half-maximal cytotoxic concentration: 47400 nM
The estimate for compound 4 lay 1.1-fold (0.02 log units) above the measured number; measured number inside the range.
By their numbers in this assay, from the lowest: compound 2; then compounds 4 and 3 (each within the scatter of the next); then compound 1.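

In this assay, this first single-place comparison gives a 1.2-fold lower number from compound 3 to compound 4 (0.07 log units; within the scatter) for a methoxy group entering on this aromatic carbon, ortho to a methoxy group and ortho to a fused ring. At this position, then, the added methoxy group leaves the number within the usual scatter. No measurement shown accounts for this result.

Going by these compounds, whether an amine or a carboxylic acid on this same carbon would also stay within the scatter remains open. So does whether a methoxy group on another carbon of this ring would.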